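Phenyl in Place of Isopropyl on the Ester Oxygen

This account rests on a few compounds, and the source may have more. Where it says the series, first, only, none or still open, it means among the compounds named here.

Measured so far:
Compound 1 `CON(C)C(=O)C1=C(c2ccc(Cl)c(Cl)c2)CCC1`: 6400 nM
Compound 2 `CC(C)OC(=O)C1=C(c2ccc(Cl)c(Cl)c2)CCC1`: 2600 nM

Of the compounds shown here, two have been measured in an assay on COS-1 cells for displacement of a labelled ligand from sodium-dependent dopamine transporter (Homo sapiens); a higher number here means a weaker inhibitor, a lower number a stronger inhibitor. Compound 1 gives 6400 nM, and compound 2 gives 2600 nM. Between them lies a 2.5-fold lower number from compound 1 to compound 2 (0.39 log units; beyond the scatter). Among the measured compounds shown here, compound 2 therefore stands at the lowest of the two numbers, with compound 1 its only neighbour, separated from it by a step beyond the scatter.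

Compound 3 `O=C(Oc1ccccc1)C1=C(c2ccc(Cl)c(Cl)c2)CCC1` has not yet been measured in this assay. It differs from compound 2 in one place: phenyl in place of isopropyl on an oxygen next to a carbonyl group. For the measured compounds named here, only one measured step exists, and it alters the group on the carbonyl carbon rather than the group on the oxygen, so it bears on the present change only loosely; it does show that a change at the ester end of the shared core moves the number modestly. A change on the oxygen is expected to do no more. Compound 3 is expected to show a 1.3-fold lower number from compound 2 to compound 3 (0.11 log units; within the scatter), a step not clearly beyond the scatter. Compound 3 is estimated at 2000 nM, within 600 nM to 7000 nM.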

Compound 3, inhibition constant: 170 nM
For compound 3 the middle estimate is 12-fold (1.07 log units) above the measured one, outside the stated range (below it).
By their numbers in this assay, from the lowest: compound 3; then compound 2; then compound 1.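

On the oxygen next to the carbonyl group, phenyl in place of isopropyl gives a 15-fold lower number from compound 2 to compound 3 (1.18 log units; beyond the scatter) in this assay and shows that this end of the shared core can move the number far more than the modest 2.5-fold lower number from compound 1 to compound 2 (0.39 log units; beyond the scatter) had suggested. Set against the methoxy(methyl)amino compound, the phenoxy group gives a 38-fold lower number from compound 1 to compound 3 (1.58 log units; beyond the scatter) and so marks the largest step among the three compounds, although the exchange of isopropyl for phenyl alters no count of hydrogen-bond donors or acceptors and adds no net charge. No measurement is available here to explain why this exchange has so large an effect.

Among the compounds shown here, with only one aromatic group on this oxygen, the compounds cannot separate a contribution of the ring itself from that of the higher carbon count, and a cyclohexyl or benzyl group in the same place would bear directly on that question. Going by these compounds, how a chlorine or methoxy group on the phenyl ring, or an anilide nitrogen in place of the ester oxygen, would shift the inhibition constant also remains open.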